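Hydrogen in place of chloro on compound 3

This account rests on a few compounds, and the source may have more. Where it says the series, first, only, none or still open, it means among the compounds named here.

In a functional assay on MCF7 cells (Homo sapiens) for antiproliferative activity, read by MTT assay, with a stated time of 72 h (on this read-out lower numbers stand for stronger inhibition and higher numbers for weaker inhibition), compound 1 `COc1cccc(N2C(=O)COc3ccc(-c4cnc(Cl)c(NS(=O)(=O)c5ccc(F)cc5)c4)cc32)c1` gives > 40000 nM as a limit of the assay and not a number. Compound 2 `O=C1COc2ccc(-c3cnc(Cl)c(NS(=O)(=O)c4ccc(F)cc4)c3)cc2N1c1ccc(F)cc1` gives 32600 nM and compound 3 `O=C1COc2ccc(-c3cnc(Cl)c(NS(=O)(=O)c4ccc(F)cc4)c3)cc2N1c1ccc(Cl)cc1` gives 32800 nM so compound 3 stands within the scatter of compound 2. Within the data shown here, compound 4 `O=C1COc2ccc(-c3cnc(Cl)c(NS(=O)(=O)c4ccc(F)cc4)c3)cc2N1c1ccccc1` has hydrogen in place of chloro on an aromatic carbon and no measured step makes that exact change. The nearest is a 1.0-fold higher number from compound 2 to compound 3 (0.00 log units; within the scatter) and it exchanges fluoro for chloro instead. The steps of an at least 1.2-fold lower number from compound 1 to compound 2 (0.08 log units; that floor lies within the scatter) and an at least 1.2-fold lower number from compound 1 to compound 3 (0.08 log units; that floor lies within the scatter) also show nothing beyond the scatter. With a 1.0-fold higher number from compound 2 to compound 3 (0.00 log units; within the scatter) as the guide, no step beyond the scatter is expected in this assay here. The expected size is a 1.0-fold higher number from compound 3 to compound 4 (0.00 log units; within the scatter) and it stays inside the scatter. Compound 4 is estimated at 33000 nM with 16000 nM to 50000 nM as its expected range.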

Compound 4, half-maximal inhibitory concentration: > 40000 nM
Compound 4 was reported as a limit; the forecaster's own chance of this, stated with the estimate: 30%; middle value at least 1.2-fold (0.08 log units) away from the limit.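

Hydrogen in place of the halogen gives an at least 1.2-fold higher number from compound 3 to compound 4 (0.08 log units; that floor lies within the scatter) and an at least 1.2-fold higher number from compound 2 to compound 4 (0.08 log units; that floor lies within the scatter) in this assay, so the first test of an unsubstituted phenyl shows no step beyond the scatter. The value of compound 4 is a limit of the assay and not a number, and compound 1 carries the same limit: the limit of > 40000 nM in this assay, at which 2 of the 4 values shown sit. The step from compound 1 to compound 4 cannot be read, and hydrogen, fluoro and chloro on this carbon remain undistinguished. On these data alone, how far compound 4 truly lies from compound 3 stays open. So does whether an amine or a carboxylic acid on this carbon would change the number.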